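Compound 3 to compound 4: leaving the methylsulfonyl group

The source may hold more compounds than are shown below. What is called first, only, known or untested is meant among the compounds shown, and "the series" means these compounds.

In a functional assay on MCF7 cells (Homo sapiens) for cytotoxicity, read by CellTiter-Glo, with a stated time of 5 days (on this read-out higher numbers stand for weaker inhibition and lower numbers for stronger inhibition), compound 1 (`CC/C(=C(/c1ccc(/C=C/C(=O)O)cc1)c1ccc2[nH]ncc2c1)c1ccc(Cl)cc1`) gives 15 nM and compound 2 (`CC/C(=C(/c1ccc(/C=C/C(=O)O)cc1)c1ccc2[nH]ncc2c1)c1ccccc1C#N`) gives 12 nM while compound 3 (`CC/C(=C(/c1ccc(/C=C/C(=O)O)cc1)c1ccc2[nH]ncc2c1)c1ccccc1S(C)(=O)=O`) gives 70 nM as the highest number of the three. Compared with compound 3, compound 4 (`CC/C(=C(/c1ccc(/C=C/C(=O)O)cc1)c1ccc2[nH]ncc2c1)c1ccc(C#N)cc1Cl`) carries 2-chloro-4-cyanophenyl in place of 2-(methylsulfonyl)phenyl on a double-bonded chain carbon bound to a double-bonded chain carbon and a saturated chain carbon. Among the measured compounds shown here, the steps that bear on this are a 4.7-fold higher number from compound 1 to compound 3 (0.67 log units; beyond the scatter) and a 5.8-fold higher number from compound 2 to compound 3 (0.77 log units; beyond the scatter) on entry of the methylsulfonyl group, with a 1.3-fold lower number from compound 1 to compound 2 (0.10 log units; within the scatter) between the 4-chlorophenyl and 2-cyanophenyl compounds. For the measured compounds named here, no measured compound carries chloro and cyano on the same ring, so this reading is indirect. With a 4.7-fold higher number from compound 1 to compound 3 (0.67 log units; beyond the scatter) as the guide, the step expected in this assay is of similar size toward a lower number, estimated as a 4.7-fold lower number from compound 3 to compound 4 (0.67 log units; beyond the scatter) on this read-out. For compound 4 the estimated value is 15 nM with an expected range from 5 nM to 45 nM in this assay.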

Compound 4, half-maximal inhibitory concentration: 4 nM
For compound 4 the middle estimate is 3.8-fold (0.57 log units) above the measured one; measured number outside the range, below it.
By their numbers in this assay, from the lowest: compound 4; then compounds 2 and 1 (each within the scatter of the next); then compound 3.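

Among the compounds shown here, changing the aryl group on this double-bonded chain carbon spans a wider range in this assay than the earlier compounds showed, with an 18-fold lower number from compound 3 to compound 4 (1.24 log units; beyond the scatter) as the largest step so far. The low end also moves, with a 3.0-fold lower number from compound 2 to compound 4 (0.48 log units; beyond the scatter) and a 3.8-fold lower number from compound 1 to compound 4 (0.57 log units; beyond the scatter) both beyond the scatter, so compound 4 now has the lowest number of the four. A ring bearing both chloro and cyano, as in 2-chloro-4-cyanophenyl, is therefore compatible with stronger inhibition here than either singly substituted ring in compound 1 or compound 2, but no measurement at hand accounts for the size of these steps.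

The compounds shown do not separate the contributions of the chloro and cyano groups. They also leave open how an amine or a carboxylic acid on this ring would read.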